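Sulfonamide series: nitro to bromo exchange before measurement

The source may report more compounds than this note shows. Statements on the series, on what has been measured and on what is new or still open speak of the compounds shown alone.

Measured so far:
compound 1, `CC(C)(C)c1ccc(S(=O)(=O)Nc2ccc(O)cc2)cc1`, 14000 nM
compound 2, `Cc1ccc(NS(=O)(=O)c2ccc([N+](=O)[O-])cc2)cc1O`, 29000 nM

In a functional assay on A549 cells (Homo sapiens) for inhibition (a higher number here means a weaker inhibitor of growth, a lower number a stronger inhibitor of growth), compound 2 gives 29000 nM, the higher of the two numbers at hand. In this assay compound 1 gives 14000 nM, and the gap between compound 1 and compound 2 lies beyond the usual scatter. For the measured compounds named here, no two measured compounds differ in a single place, so no measured step exists for any one structural change.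

Compound 3, `Cc1ccc(NS(=O)(=O)c2ccc(Br)cc2)cc1O`, is the next to be measured in this assay. It keeps the core of compound 2 and differs from it by bromo in place of nitro on an aromatic carbon. Going by the values given here, with no measured step for this kind of change, only a small effect is expected, in either direction or none beyond the scatter. The estimate for compound 3 in this assay is 20000 nM, expected to fall between 6000 nM and 60000 nM. The step this estimate means, a 1.5-fold lower number from compound 2 to compound 3 (0.16 log units; within the scatter), is expected to stay modest.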

Compound 3, concentration for 50% growth inhibition: 20000 nM
Compound 3: middle estimate and measured number agree at the digits printed, and the stated range covers the measured number.
By their numbers in this assay, from the lowest: compounds 1, 3 and 2 (each within the scatter of the next, the first and the last beyond it).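

In this assay, for the compounds shown here, bromo in place of nitro on an aromatic carbon, para to a large group, gives a 1.5-fold lower number from compound 2 to compound 3 (0.16 log units; within the scatter) and is the first single-place step. At this position, nitro with its hydrogen-bond acceptors can therefore give way to bromo, which has none, without a shift beyond the scatter. No measurement at hand bears on the reason for this result.

Going by these compounds alone, whether an amine, a carboxylic acid or a methoxy group at this position would move the number beyond the scatter stays open, since nitro and bromo are the only groups compared here. On these data alone, compound 1 differs from compound 2 in more than one place, so the contribution of each remaining part of the core also stays open.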